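This account rests on a few compounds, and the source may have more. Where it says the series, first, only, none or still open, it means among the compounds named here.

Compound 1 `CCCCc1cnc(Cc2ccc(-c3ccccc3C(=O)O)cc2)[nH]1`: > 10000 nM
Compound 2 `O=C(O)c1ccccc1-c1ccc(CCc2ncc(CC3CCCC3)[nH]2)cc1`: 7.9 nM

For the measured compounds named here, in an in vitro functional assay on cells for agonist activity at Bombesin receptor subtype-3 (Mus musculus), read by luminescence and calcium flux (on this read-out lower numbers stand for an effect already at smaller amounts and higher numbers for an effect only at larger amounts of compound), compound 2 gives 7.9 nM, the only number among the two values shown. For compound 1 the value of > 10000 nM is a limit of the assay, and (the limit of > 10000 nM in this assay, at which 1 of the 2 values shown sits). Compound 3 `N#Cc1ccc(Cc2cnc(CCc3ccc(-c4ccccc4C(=O)O)cc3)[nH]2)cc1` differs from compound 2 in one place: 4-cyanophenyl in place of cyclopentyl on a saturated chain carbon bound to an aromatic carbon. Going by the values given here, no measured pair shows a change of this kind, so the size of the step cannot be read from the data. Compound 3 is expected to stay active, with a step of a 2.5-fold higher number from compound 2 to compound 3 (0.40 log units; beyond the scatter) that is estimated to be small, near or slightly beyond the usual scatter. The estimate for compound 3 is 20 nM, ranging from 4 nM to 100 nM.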

Compound 3, half-maximal effective concentration: 723 nM
Estimate against measurement, compound 3: 36-fold (1.56 log units) below; the whole stated range lies below it.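

Replacing cyclopentyl with 4-cyanophenyl on a saturated chain carbon bound to an aromatic carbon gives a 92-fold higher number from compound 2 to compound 3 (1.96 log units; beyond the scatter) in this assay as a large step. For the compounds shown here, this is the first pair to show that the group at this place strongly changes the effect, yet compound 3 still gives a measured number rather than a limit. Nothing shown here explains the size of this step.

On these data alone, whether the aromatic ring or the nitrile goes with the change stays open. A plain benzyl group or a cyclohexylmethyl group at this place would help separate the two.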